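From ethylamino to propylamino in compound 1

The source may hold more compounds than are shown below. What is called first, only, known or untested is meant among the compounds shown, and "the series" means these compounds.

Compound 1, `CCNc1cc(-c2ccc(NC(=O)Nc3cccc(Cl)c3)cc2C(F)(F)F)ccn1`: 13300 nM
Compound 2, `CCNc1cc(-c2ccc(NC(=O)Nc3ccc(C(F)(F)F)cc3)cc2C(F)(F)F)ccn1`: 16400 nM
Compound 3, `CCNc1cc(-c2ccc(NC(=O)Nc3cccc(Cl)c3)cc2F)ccn1`: 18500 nM
Compound 4, `CCCNc1cc(-c2ccc(NC(=O)Nc3cccc(Cl)c3)cc2C(F)(F)F)ccn1`: not yet measured

These values come from a functional assay on BT-483 cells (Homo sapiens) for cytotoxicity, read by MTT assay, with a stated time of 24 h; on this read-out lower numbers stand for stronger inhibition and higher numbers for weaker inhibition. Compound 1 gives 13300 nM and is not clearly separated from its two close relatives, since both steps away from it stay within the normal scatter of repeated measurements.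

Compound 4 differs from compound 1 at a single place: methyl in place of hydrogen on a saturated chain carbon, two bonds along the chain from a nitrogen on an aromatic ring. Put simply, the ethylamino group becomes a propylamino group.

Two measured steps offer some guidance. Putting 4-(trifluoromethyl)phenyl in place of 3-chlorophenyl gave a 1.2-fold higher number from compound 1 to compound 2 (0.09 log units; within the scatter), and putting fluoro in place of trifluoromethyl gave a 1.4-fold higher number from compound 1 to compound 3 (0.14 log units; within the scatter). Among the compounds with values here, neither step touches the ethylamino chain, so no measured pair tests this change directly. They show only that two other edits left the number within the scatter in this assay.

Going by these compounds, with so little evidence, no shift beyond the scatter is expected, and the direction remains open. The estimated change is a 1.1-fold higher number from compound 1 to compound 4 (0.02 log units; within the scatter). For compound 4 the expected value is 14000 nM, with an estimated range from 7000 nM to 28000 nM.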

Compound 4, half-maximal inhibitory concentration: 18500 nM
Estimate against measurement, compound 4: 1.3-fold (0.12 log units) below; the range from low to high includes it.
By their numbers in this assay, from the lowest: compounds 1, 2, 3 and 4 (each within the scatter of the next).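

Within the data shown here, the step from ethylamino to propylamino is the first direct test of the chain on this nitrogen: in this assay, it gives a 1.4-fold higher number from compound 1 to compound 4 (0.14 log units; within the scatter). The earlier compounds shown here varied only the groups on the aromatic rings, whereas this pair shows that adding a methyl at this saturated chain carbon also leaves the number within the usual scatter, at least on the core of compound 1. Nothing measured here speaks to the reason for this result.

Going by these compounds, whether a longer chain such as butylamino, a branched chain such as isopropylamino, or a chain ending in an amine or a carboxylic acid would move the number beyond the scatter remains open. A single pair also cannot show whether the same change from ethylamino to propylamino would behave alike alongside the 4-(trifluoromethyl)phenyl group of compound 2 or the fluoro group of compound 3.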